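A few compounds are considered here, and "the series" means these few. Any claim that something is new, unique, unknown or untested is made for them only; others in the source may bear on it.

In an ADME assay on Vero cells (Chlorocebus sabaeus) for cytotoxicity, with a stated time of 3 days (a lower number here means a stronger inhibitor, a higher number a weaker inhibitor), compound 1 `CCN(CC)c1cc2[nH]c(-c3ccc(F)cc3)nc2cc1NC(=O)C1CCC1` gives > 200 ug/mL, which is a limit of the assay rather than a measured number. Compound 2 `O=C(Nc1cc2nc(-c3cccs3)[nH]c2cc1N1CCCCC1)OCc1ccccc1` likewise gives > 200 ug/mL, again only a limit. Compound 3 `CCN(CCN(C)C)c1cc2[nH]c(C3CCCCC3)nc2cc1NS(=O)(=O)c1ccccc1` gives > 200 ug/mL, also a limit, so it stands exactly where the other two stand: at the limit of > 200 ug/mL in this assay, at which 3 of the 3 values shown sit. Compound 4 `CN(C)CCN(C)c1cc2[nH]c(C3CCCCC3)nc2cc1NS(=O)(=O)c1ccccc1` has not yet been measured. It differs from compound 3 by hydrogen in place of methyl on a saturated chain carbon bound to a nitrogen on an aromatic ring. For the measured compounds named here, with no measured step available for comparison, the expected step that the limit leaves unreadable from compound 3 to compound 4 is none beyond the usual scatter. Compound 4 is therefore estimated at 250 ug/mL, between 150 ug/mL and 400 ug/mL, most likely reported only as a limit once more.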

Compound 4, half-maximal inhibitory concentration: > 200 ug/mL
Compound 4 gave a limit, no number; the forecaster's own chance of this, stated with the estimate: 85%; the middle value does not contradict the limit.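

In this assay, for the compounds shown here, compound 3 and compound 4 both give only a limit, so no step between them can be read: the limit of > 200 ug/mL in this assay, at which 4 of the 4 values shown sit. The compounds shown leave open whether any of them truly differs from another in this assay, and what actual number each would give.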